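The source may hold more compounds than are shown below. What is called first, only, known or untested is meant among the compounds shown, and "the series" means these compounds.

Measured compounds:
- compound 1, `CC(C)=CCCC1=C[C@@H](C/C(C)=C/CC/C(C)=C/CC2=CC(=O)C=C(C)C2=O)OC1=O`: 5900 nM
- compound 2, `CC(C)=CCC/C(=C/CC/C(C)=C/CC[C@]1(C)C=Cc2cc(O)cc(C)c2O1)C(=O)O`: 9000 nM

In a functional assay on CV-1 cells for antagonist activity at Bile acid receptor (Homo sapiens), read by a luciferase reporter, with a stated time of 24 h (on this read-out lower numbers stand for stronger inhibition and higher numbers for weaker inhibition), compound 1 gives 5900 nM and compound 2 gives 9000 nM. Of these two numbers, that of compound 2 is the larger, but its gap to compound 1 lies within the usual scatter of repeated measurements, so the two cannot be told apart on this read-out. Among the measured compounds shown here, no pair of measured compounds differs in only one place, so no measured step is available as a guide.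

Compound 3, `CC(C)=CCC/C(=C/CC/C(C)=C/CC[C@@]1(C)C=Cc2cc(O)cc(C)c2O1)C(=O)O`, is not yet measured. Compared with compound 2, (the two compounds have the same atoms and bonds and differ only in configuration as drawn: 1 of 3 stereo elements differ; a stereocentre at a saturated ring carbon is drawn R in compound 2 and S in compound 3). For the measured compounds named here, nothing among the measured compounds shows how this assay responds to a change of configuration at that ring carbon, so the direction of any step is open. The expectation is that the step of no change at the digits printed from compound 2 to compound 3 (within the scatter) is none beyond the scatter, with a wide range to allow for either direction. Compound 3 is therefore estimated at 9000 nM in this assay, with a range from 2500 nM to 32000 nM.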

Compound 3, half-maximal inhibitory concentration: 17000 nM
Estimate against measurement, compound 3: 1.9-fold (0.28 log units) below, within the range that was stated.
By their numbers in this assay, from the lowest: compounds 1, 2 and 3 (each within the scatter of the next, the first and the last beyond it).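

Turning the stereocentre at the saturated ring carbon from R to S gives the first measured step in this set (a 1.9-fold higher number from compound 2 to compound 3 (0.28 log units; within the scatter)) in this assay, and that step stays within the scatter. Among the compounds shown here, the two configurations therefore cannot be told apart on this read-out, and the earlier compounds, which offered no pair differing in one place, could not show this. The step can be tied to this one stereocentre alone because nothing else separates the pair: the fact that compounds 2 and 3 differ only in the configuration as drawn.

From the compounds shown here alone, what remains open is whether the configuration at this ring carbon stays as silent when other parts of the molecule are changed, for instance with a methyl ester in place of the carboxylic acid or a methoxy group in place of the ring hydroxyl. For the compounds shown here, also open is how either form would respond to a shorter chain in place of the present one, since only this single change of configuration has been read so far.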